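From hydroxy to anilino on compound 1

The compounds below may be only part of what the source reports. "The series", "measured", "known", "first", "only" and "open" are said of these compounds alone.

compound 1 `CC(=O)SCCC(CCCCC(=O)O)SC(C)=O`: 9.89%
compound 2 `O=C(CCCCC(S)CCS)Nc1cccc(Cl)c1`: 7.2%
compound 3 `O=C(CCCCC(S)CCS)Nc1ccc(Cl)cn1`: "not active" (no number reported)

These compounds were tested in a functional assay on NCI-H460 cells (Homo sapiens) for inhibition, read by MTT assay, with a stated time of 24 h, tested at 1 ug/mL (a higher number here means more inhibition of growth at the concentration tested, a lower number less inhibition of growth), and none shows much effect. Compound 1 stands level with compound 2, as their two numbers lie within the usual scatter of each other. Compound 3 offers no number for comparison, only the report "not active" (no number reported) in place of a figure.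

Compound 4 `CC(=O)SCCC(CCCCC(=O)Nc1ccccc1)SC(C)=O` has not yet been measured. It differs from compound 1 by one change, anilino in place of hydroxy on a carbonyl carbon and this turns the acid into an amide. Compound 2 and compound 3 also carry an aromatic ring on an amide, although they differ from compound 4 elsewhere. Compound 2 gives 7.2% here, which offers no sign of a large gain. No step beyond the scatter is expected in this assay and the estimated change is a number 1.1 percentage points higher from compound 1 to compound 4 (within the scatter) as a rough figure. For compound 4 the expected value is 11% within an estimated range of 2% to 28% in this test.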

Compound 4, percent growth inhibition at one concentration: 13.1%
Compound 4: the middle estimate sits 2.1 percentage points below what was measured, and the stated range covers the measured number.
By their numbers in this assay, from the lowest: compounds 2, 1 and 4 (each within the scatter of the next).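

Among these compounds, compound 1 and compound 4 form the first pair here that differs in one place, which gives the first direct look at the carbonyl carbon of the shared core. In this assay, anilino in place of hydroxy gives a number 3.2 percentage points higher from compound 1 to compound 4 (within the scatter) even though seven heavy atoms and a six-membered aromatic ring enter where a single oxygen leaves, so turning the acid into this amide brings no clear change in growth inhibition. No measurement shown here offers an explanation for this result.

Going by these compounds, it remains open whether any other group on this carbonyl carbon, such as benzylamino or morpholino, would shift the number beyond the scatter. Also open, on these data alone, is whether a larger effect would appear at another concentration in this assay for these compounds.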